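This account rests on a few compounds, and the source may have more. Where it says the series, first, only, none or still open, it means among the compounds named here.

Measured compounds in a functional assay on MCF7 cells (Homo sapiens) for cytotoxicity, read by MTT assay, with a stated time of 72 h; on this read-out higher numbers stand for weaker inhibition and lower numbers for stronger inhibition:
Compound 1 `C[C@@H](Nc1c(C(=O)NCc2ccc(F)cc2)nc(Br)c2cccnc12)c1ccccc1` — "not determined" (no result reported).
Compound 2 `N[C@H]1CC[C@H](Nc2c(C(=O)NCc3ccccn3)nc(Br)c3cccnc23)CC1` — 15000 nM.
Compound 3 `NCCNc1c(C(=O)NCc2ccc(F)cc2)nc(Br)c2cccnc12` — 6000 nM.

Compound 3 gives the lower of the two numbers in this assay; compound 2 stands above it, beyond the scatter. Within the data shown here, the two differ in more than one place, so the pair shows only its two values and no single step.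

Compound 4 `NCCCNc1c(C(=O)NCc2ccc(F)cc2)nc(Br)c2cccnc12` differs from compound 3 in one place: aminomethyl in place of amino on a saturated chain carbon, two bonds along the chain from a nitrogen on an aromatic ring. Among the measured compounds shown here, no step of this kind between measured compounds is available to anchor the size, so the expectation rests on the change being aminomethyl in place of amino on the chain only. The expected step is a 1.1-fold lower number from compound 3 to compound 4 (0.04 log units; within the scatter), none beyond the scatter. For compound 4 the estimate in this assay is 5500 nM, ranging from 2000 nM to 16000 nM.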

Compound 4, half-maximal inhibitory concentration: 6000 nM
For compound 4 the middle estimate is 1.1-fold (0.04 log units) below the measured one; the range from low to high includes it.
By their numbers in this assay, from the lowest: compounds 3 and 4 (each within the scatter of the next); then compound 2.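

In this assay, among these compounds, the change from (2-aminoethyl)amino to (3-aminopropyl)amino gives no change at the digits printed from compound 3 to compound 4 (within the scatter) and provides the first single-place step. On this saturated chain, aminomethyl in place of amino leaves the number unmoved, something the pair of compound 2 and compound 3 could not show, since they differ in more than one place. No measurement at hand explains this result. Still open, as far as these compounds go, is whether a longer chain such as (4-aminobutyl)amino, or a carboxylic acid in place of the amine, would move the number beyond the scatter.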